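Swapping the aniline ring in a urea series

This account rests on a few compounds, and the source may have more. Where it says the series, first, only, none or still open, it means among the compounds named here.

Measured so far:
- compound 1, `Cc1ccc(Nc2cc(NC(=O)Nc3c(Cl)cccc3Cl)ncn2)cc1C`: 47.5%
- compound 2, `COc1cc(NC(=O)Nc2cc(Nc3ccc(C)c(C)c3)ncn2)cc(OC)c1`: 29.5%
- compound 3, `COc1cc(NC(=O)Nc2cc(Nc3cc(C(F)(F)F)ccc3OC)ncn2)cc(OC)c1`: 63%

All three were tested in a functional assay on NCI-H520 cells (Homo sapiens) for inhibition, read by MTT assay, with a stated time of 48 h, tested at 10 uM; on this read-out higher numbers stand for more inhibition at the one concentration tested (going by the name of the read-out) and lower numbers for less inhibition. Compound 2 stands lowest of the three numbers; compound 1 sits higher by a margin beyond the scatter, and compound 3 higher still, also beyond the scatter. The unmeasured compound 4, `COc1cc(NC(=O)Nc2cc(Nc3ccc(Br)cc3OC)ncn2)cc(OC)c1`, keeps the core of compound 2 and changes one ring: 4-bromo-2-methoxyphenyl in place of 3,4-dimethylphenyl on a nitrogen on an aromatic ring. Among the compounds with values here, no step between measured compounds is directly comparable, yet compound 3, which also carries a methoxy-bearing aniline, gives 63%. On that basis the change is expected to lift inhibition, a step of a number 20.5 percentage points higher from compound 2 to compound 4 (beyond the scatter), with compound 4 estimated at 50%, somewhere between 30% and 70%.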

Compound 4, a percentage reported as inhibition, at one concentration (the size of the read-out at that concentration, not a potency): 36.1%
Beside the measured number, compound 4's estimate is 13.9 percentage points above it; measured number inside the range.
By their numbers in this assay, from the lowest: compounds 2 and 4 (each within the scatter of the next); then compound 1; then compound 3.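

In this assay the move from 3,4-dimethylphenyl to 4-bromo-2-methoxyphenyl on a nitrogen on an aromatic ring gives no readable change (a number 6.6 percentage points higher from compound 2 to compound 4 (within the scatter)). At this position, then, the two rings cannot be told apart, even though they differ in both their groups and their substitution pattern. No measurement shown here offers an explanation for this result.

Going by these compounds, whether the bromine or the methoxy has any effect alone remains open, since the two enter together. Also open, on these data alone, is how this ring would respond to an amine or a carboxylic acid.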